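Antiproliferative series on the shared core: aryl swap at the pyrazole carbon

The compounds below may be only part of what the source reports. "The series", "measured", "known", "first", "only" and "open" are said of these compounds alone.

Measured so far:
compound 1, `Cc1nn(-c2nc(-c3ccc(Cl)c(Cl)c3)c(SC(C)C)s2)c(C(=O)O)c1-c1cccc(C(F)(F)F)c1`, 22000 nM in a functional assay on BJAB cells (Homo sapiens) for antiproliferative activity, with a stated time of 4 days; on this read-out lower numbers stand for an effect already at smaller amounts and higher numbers for an effect only at larger amounts of compound
compound 2, `CCOc1ncccc1-c1c(C)nn(-c2nc(-c3ccc(Cl)c(Cl)c3)c(SC(C)C)s2)c1C(=O)O`, 11000 nM in this assay

Going by the values given here, compound 2 gives the lowest of the two numbers in this assay, with compound 1 as its only neighbour; the step of a 2.0-fold lower number from compound 1 to compound 2 (0.30 log units; within the scatter) is within the scatter, so the two compounds are not distinguished on these data.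

Compound 3, `Cc1nn(-c2nc(-c3ccc(Cl)c(Cl)c3)c(SC(C)C)s2)c(C(=O)O)c1-c1cc(C#N)cc(C(F)(F)F)c1`, is not yet measured. It differs from compound 2 by 3-cyano-5-(trifluoromethyl)phenyl in place of 2-ethoxypyridin-3-yl on an aromatic carbon. Compared with compound 1 it carries an additional nitrile on the same ring, a change for which no measured pair exists in the series.

Among the compounds with values here, the only step that bears on this position is the one from compound 1 to compound 2, and it stayed within the scatter. Within the data shown here, nothing here indicates that a change at this carbon moves the number beyond the scatter, and the nitrile has no precedent. The expectation for compound 3 in this assay is therefore a number close to those of compounds 1 and 2, estimated as 15000 nM with a range of 5000 nM to 45000 nM. This estimate corresponds to an expected step of a 1.4-fold higher number from compound 2 to compound 3 (0.13 log units; within the scatter), which is within the scatter.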

Compound 3, half-maximal effective concentration: 3600 nM
Estimate against measurement, compound 3: 4.2-fold (0.62 log units) above; measured number below the stated range.
By their numbers in this assay, from the lowest: compound 3; then compounds 2 and 1 (each within the scatter of the next).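

In this assay, the aromatic carbon next to the ring atom that bears a carboxy group now shows a response to the aryl group it carries: 3-cyano-5-(trifluoromethyl)phenyl in place of 2-ethoxypyridin-3-yl gives a 3.1-fold lower number from compound 2 to compound 3 (0.49 log units; beyond the scatter), whereas the earlier pair of compounds could not be told apart. The more specific reading comes from the single added nitrile, since cyano in place of hydrogen, with the trifluoromethyl kept on the same ring, gives a 6.1-fold lower number from compound 1 to compound 3 (0.79 log units; beyond the scatter) and so places the change in one substituent of the aryl group rather than in an exchange of the whole ring. No measurement on these compounds accounts for either step.

Still open, going by these compounds, is whether the nitrile is specifically needed at that ring carbon, or whether an amine, a methoxy group or a carboxylic acid there would give a similar number, and whether the nitrile would do so without the trifluoromethyl alongside it. Also open, on these data alone, is whether the step would persist with an amide in place of the carboxy group on the shared core.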